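The source may report more compounds than this note shows. Statements on the series, on what has been measured and on what is new or still open speak of the compounds shown alone.

Measured so far in an ADME assay on HEL cells (Homo sapiens) for cytotoxicity; a higher number here means that more compound is tolerated, a lower number that less compound is tolerated:

Compound 1 `O=C(COc1cccc2ccccc12)N/N=C/c1c(O)ccc2ccccc12` gives 4 ug/mL in this assay.
Compound 2 `O=C(COc1cccc2ccccc12)N/N=C/c1ccc(Cl)cc1` gives 100 ug/mL in this assay.
Compound 3 `C/C(=N\NC(=O)COc1cccc2ccccc12)c1ccc(O)cc1O` reaches only a limit of the assay in this assay, > 100 ug/mL.

Compound 2 therefore holds the higher of the two numbers actually read out in this assay; the nearest measured value is that of compound 1, which sits far lower, a gap well beyond the scatter of repeated runs. Compound 3 gives no number, only a limit, and so cannot be ranked against compound 2 beyond saying that it was tolerated up to the top of the range tested.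

Compound 4 `O=C(COc1cccc2ccccc12)N/N=C/c1ccc(Br)cc1` has not yet been measured. It differs from compound 2 in one place: bromo in place of chloro on an aromatic carbon. Cut one bond further out, the change reads 4-chlorophenyl to 4-bromophenyl. For the measured compounds named here, with no measured pair showing a halogen swap, the step can only be expected to be small. Compound 4 is estimated to give 100 ug/mL in this assay, with a range from 50 ug/mL to 200 ug/mL, which means an expected step of no change at the digits printed from compound 2 to compound 4 (within the scatter), none beyond the scatter.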

Compound 4, minimum cytotoxic concentration: > 100 ug/mL
Compound 4: no number, only a limit (the forecaster's own chance of this, stated with the estimate: 30%); the middle value lies on the limit itself.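

This is the first pair among the compounds shown that differs in one place, and it shows that on this aromatic carbon, para to a large group, bromo in place of chloro gives a number no lower from compound 2 to compound 4 (the limit leaves the size open) in this assay. Compound 4 reads > 100 ug/mL, which is a limit of the assay and not a number. The change from 4-chlorophenyl to 4-bromophenyl therefore brings no drop that can be read at this position, but the size of the step cannot be stated, because the read-out ends where these compounds sit: the limit of > 100 ug/mL in this assay, at which 2 of the 4 values shown sit.

The compounds shown leave open whether this position stays as tolerant with a group that is not a halogen, such as an amine, a carboxylic acid or a methoxy group, in place of the chloro or the bromo. They also leave open whether fluoro would follow chloro and bromo here, and whether the same halogen swap would read the same way at another place on the shared core.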